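A few compounds are considered here, and "the series" means these few. Any claim that something is new, unique, unknown or untested is made for them only; others in the source may bear on it.

Working notes on the series.

Among the compounds with values here, compound 1 `O=C(CCc1ccccc1)Nc1nc2ccccc2c(=O)s1` is the only member with a numeric read-out: in an assay on CHO cells for displacement of a labelled ligand from adenosine receptor A3 (Homo sapiens), read by scintillation counting, with a stated time of 60 min (on this read-out lower numbers stand for stronger inhibition and higher numbers for weaker inhibition), compound 1 gives 390 nM. Compound 3 `O=C(CCc1ccccc1Br)Nc1nc2ccccc2c(=O)s1` reaches only the limit of this assay, > 1000 nM. Within the data shown here, the one single-point step measured so far, an at least 2.5-fold higher number from compound 1 to compound 3 (0.40 log units; beyond the scatter), therefore puts a halogen on an aromatic carbon on the weaker side, and the limit of > 1000 nM in this assay, at which 2 of the 3 values shown sit, marks where compound 3 sits.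

Compound 2 `COc1cccc(/C=C/C(=O)Nc2nc3ccccc3c(=O)s2)c1` likewise returns only the limit of this assay, > 1000 nM. Compound 2 thus stands at the weaker end of the numbers shown, with no number of its own.

Compound 4 `O=C(/C=C/c1cccc(Cl)c1)Nc1nc2ccccc2c(=O)s1` differs from compound 2 by chloro in place of methoxy on an aromatic carbon. Among the measured compounds shown here, no measured step swaps methoxy for chloro; the nearest evidence is the weakening seen in an at least 2.5-fold higher number from compound 1 to compound 3 (0.40 log units; beyond the scatter) on adding a halogen, which gives no ground to expect a move below the limit. Compound 4 is therefore expected to give about 1500 nM in this assay, within 500 nM to 5000 nM. The expected step that the limit leaves unreadable from compound 2 to compound 4 is estimated to stay within the scatter.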

Compound 4, inhibition constant: > 1000 nM
Compound 4 was reported as a limit; the forecaster's own chance of this, stated with the estimate: 60%; the middle value lies beyond the limit too.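

Compound 2 and compound 4 both return only a limit in this assay, so no step between them can be read: the limit of > 1000 nM in this assay, at which 3 of the 4 values shown sit.

The compounds shown leave open whether 3-methoxyphenyl and 3-chlorophenyl differ at all in this assay.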